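The compounds below may be only part of what the source reports. "The series", "measured", "known", "first", "only" and "open" are said of these compounds alone.

The measured compounds:
compound 1, `CC(C)n1c(=O)n(C(=O)NCC2CCNCC2)c2ccccc21`, 92%
compound 2, `CC(C)n1c(=O)n(C(=O)NC2CCNCC2)c2ccccc21`, > 100%

In a functional assay on HEK293 cells for activation of 5-hydroxytryptamine receptor 4 (Homo sapiens), read by cAMP accumulation (on this read-out higher numbers stand for larger maximal responses and lower numbers for smaller maximal responses), compound 1 gives 92%. Compound 2 reaches > 100% in this assay, which is a limit of the assay and not a number (the limit of > 100% in this assay, at which 1 of the 2 values shown sits). So compound 2 stands where this assay stops reporting numbers. Within the data shown here, the one measured step, a number at least 8 percentage points higher from compound 1 to compound 2 (that floor lies within the scatter), changed the group on the amide-type nitrogen. Compound 3, `CC(C)n1c(=O)n(C(=O)NCCN2CCNCC2)c2ccccc21`, has not yet been measured. It differs from compound 2 at that same amide-type nitrogen: 2-(piperazin-1-yl)ethyl in place of piperidin-4-yl on an amide-type nitrogen. No measured step involves a 2-(piperazin-1-yl)ethyl group, so the direction of the step in this assay is not shown by the data. Compound 3 is expected to stay a strong activator, with a step of a number at least 10 percentage points lower from compound 2 to compound 3 (that floor lies within the scatter) that is estimated to be small. Compound 3 is estimated at 90%, between 60% and 105%.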

Compound 3, intrinsic activity: the largest response reached, in percent of the reference agonist's: > 100%
Compound 3: a limit, no number; the forecaster's own chance of this, stated with the estimate: 35%; at least 10 percentage points between middle value and limit.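

In this assay compound 3 gives > 100%, which is a limit of the assay and not a number, so the amide-type nitrogen can carry 2-(piperazin-1-yl)ethyl, a larger group with a second ring nitrogen, and the response still reaches the limit seen with piperidin-4-yl. Measured against the (piperidin-4-yl)methyl group, the change gives a number at least 8 percentage points higher from compound 1 to compound 3 (that floor lies within the scatter), so this comparison does not establish a real gain. The step between the two compounds at the limit cannot be read, and no order can be given for them because the assay reports no number there: the limit of > 100% in this assay, at which 2 of the 3 values shown sit.

Still open, from the compounds shown here alone, is how a group with no ring nitrogen, such as a plain butyl chain, or a chain ending in a carboxylic acid, would behave on this amide-type nitrogen. Also open, going by these compounds, is whether a longer chain leading to the piperazine ring would keep the response at the limit.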